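The source may report more compounds than this note shows. Statements on the series, on what has been measured and on what is new or still open speak of the compounds shown alone.

Measured compounds in a functional assay on HCT-116 cells (Homo sapiens) for antiproliferative activity, read by MTT assay, with a stated time of 72 h; on this read-out higher numbers stand for weaker inhibition and lower numbers for stronger inhibition:
compound 1, `CCC(=O)N(C)c1ccc2[nH]c(-c3n[nH]c4ccccc34)cc2n1`, gives 10800 nM;
compound 2, `CN(C(=O)c1ccccc1)c1ccc2[nH]c(-c3n[nH]c4ccccc34)cc2n1`, gives 10600 nM;
compound 3, `Cc1ccc(S(=O)(=O)N(C)c2ccc3[nH]c(-c4n[nH]c5ccccc45)cc3n2)cc1`, gives 13300 nM.

All three share one core and differ only in the group on the nitrogen that carries the methyl. Compound 3 sits with the others rather than apart from them: the change from compound 1 to compound 3 gives a 1.2-fold higher number from compound 1 to compound 3 (0.09 log units; within the scatter), and the change from compound 2 to compound 3 gives a 1.3-fold higher number from compound 2 to compound 3 (0.10 log units; within the scatter). Likewise the change from compound 1 to compound 2 gives a 1.0-fold lower number from compound 1 to compound 2 (0.01 log units; within the scatter). Every change tried at this nitrogen, whether propanoyl, benzoyl or (4-methylphenyl)sulfonyl, has left the number where it was.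

Compound 4, `COc1ccc(OC)c(S(=O)(=O)N(C)c2ccc3[nH]c(-c4n[nH]c5ccccc45)cc3n2)c1`, keeps the sulfonyl of compound 3 and alters the ring on the sulfonyl sulfur: 2,5-dimethoxyphenyl in place of 4-methylphenyl on a sulfonyl sulfur. Among the measured compounds shown here, no measured step alters the aryl group on a sulfonyl sulfur, so the steps bear on it only by showing how little this nitrogen substituent has mattered so far. Compound 4 is therefore expected to give a step of a 1.0-fold lower number from compound 3 to compound 4 (0.01 log units; within the scatter), that is, none beyond the scatter. Compound 4 is estimated at 13000 nM, within a range from 5000 nM to 35000 nM.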

Compound 4, half-maximal inhibitory concentration: 8400 nM
For compound 4 the middle estimate is 1.5-fold (0.19 log units) above the measured one; measured number inside the range.
By their numbers in this assay, from the lowest: compounds 4, 2, 1 and 3 (each within the scatter of the next).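

Changing the aryl group on the sulfonyl sulfur of the shared core, with 2,5-dimethoxyphenyl replacing 4-methylphenyl, gives in this assay a 1.6-fold lower number from compound 3 to compound 4 (0.20 log units; within the scatter), so this exchange does not move the number beyond the usual spread. The earlier steps shown here varied only the whole group on the sulfonamide nitrogen, whereas this one shows that the ring on the sulfur can also take two methoxy groups, and with them two hydrogen-bond acceptors, without a change that can be told from scatter. Nothing available explains this result.

Going by these compounds, whether an amine or a carboxylic acid on this ring would shift the number remains open. So does the effect of a small alkyl group such as methyl in place of the aryl group on the sulfur, or of hydrogen in place of the methyl on the sulfonamide nitrogen.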